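Removing One Methoxy Group: What to Expect for Compound 4

This account rests on a few compounds, and the source may have more. Where it says the series, first, only, none or still open, it means among the compounds named here.

Three compounds have been measured in a functional assay on OVCAR-8 cells (Homo sapiens) for cytotoxicity, read by sulforhodamine B assay, with a stated time of 48 h, tested at 1 uM; on this read-out lower numbers stand for a stronger effect and higher numbers for a weaker effect at the one concentration tested:

Compound 1, `COc1cc(-c2cc(/C=C/C(=O)c3ccc(N)cc3)[nH]n2)cc(OC)c1OC`, gives 81%.
Compound 2, `COc1ccc(-c2cc(/C=C/C(=O)c3ccc(N)cc3)[nH]n2)cc1OC`, gives 93%.
Compound 3, `COc1cc(C(=O)/C=C/c2cc(-c3cc(OC)c(OC)c(OC)c3)n[nH]2)cc(OC)c1OC`, gives 81%.

Compound 1 and compound 2 share one core and differ in a single place: hydrogen in place of methoxy on an aromatic carbon. This change produced a number 12 percentage points higher from compound 1 to compound 2 (beyond the scatter), a modest weakening of the effect at the single concentration tested.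

Compound 3 is built on a different core; the difference between the two cores is not broken down here. Its value in this assay sits level with that of compound 1 at the digits reported, so the two cannot be told apart within the usual scatter.

Compound 4, `COc1ccc(-c2cc(/C=C/C(=O)c3cc(OC)c(OC)c(OC)c3)[nH]n2)cc1OC`, has not yet been measured. It differs from compound 3 by hydrogen in place of methoxy on an aromatic carbon, the same change as from compound 1 to compound 2, made in identical surroundings.

Because the earlier step was a number 12 percentage points higher from compound 1 to compound 2 (beyond the scatter), the step from compound 3 to compound 4 is expected to be a number 11 percentage points higher from compound 3 to compound 4 (beyond the scatter). This expectation rests on one example only. Compound 4 is therefore estimated at 92%, within a range from 82% to 100%.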

Compound 4, a percentage reported as activity, at one concentration (the size of the read-out at that concentration, not a potency): 80%
Compound 4: middle estimate off by 12 percentage points, on the high side; measured number below the stated range.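

In this assay, putting hydrogen in place of the methoxy group gave a number 1 percentage points lower from compound 3 to compound 4 (within the scatter) on this second core, a step too small to tell apart from ordinary repeat-to-repeat variation. Among these compounds, the result does not show that the change carries over unaltered from one core to the other, and it does not show that the core alters the change: with only two examples, a true difference between the cores and plain scatter both remain possible. Set side by side, the two steps cannot be separated: the same change on two cores in this assay, a number 12 percentage points higher (beyond the scatter) from compound 1 to compound 2 and a number 1 percentage points lower (within the scatter) from compound 3 to compound 4, 13 percentage points apart, within the scatter of two such steps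

The compounds shown test only the swap between methoxy and hydrogen at this one place on two cores, leaving open how a third core would respond and what another group there, such as an amine, a carboxylic acid or a longer chain, would do. As far as these compounds go, each compound also has a reading at just one concentration, and how its effect changes with dose remains open.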